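A few compounds are considered here, and "the series" means these few. Any claim that something is new, unique, unknown or untested is made for them only; others in the source may bear on it.

The three measured compounds:
Compound 1 `CCCCNc1nc(N)nc(C)c1CCc1ccccc1` gives 1190 nM in an assay on HEK293 cells for agonist activity at Toll-like receptor 8 (Homo sapiens), read by spectrophotometry; a higher number here means that more compound is needed for the effect, a lower number that less compound is needed.
Compound 2 `CCCCNc1nc(N)nc(C)c1CCCC` gives 780 nM in this assay.
Compound 3 `CCCCCc1c(C)nc(N)nc1NCCCC` gives 1220 nM in this assay.

All three share one core and differ only in the saturated chain hanging from it. Going from compound 2 to compound 1 the change is phenyl in place of ethyl on a saturated chain carbon, two bonds along the chain from an aromatic carbon, and the step it made was a 1.5-fold higher number from compound 2 to compound 1 (0.18 log units; within the scatter). Compound 2 and compound 3 differ in their cores by methyl in place of hydrogen on a saturated chain carbon, four bonds along the chain from an aromatic carbon, and that step was a 1.6-fold higher number from compound 2 to compound 3 (0.19 log units; within the scatter). The same kind of change that led from compound 2 to compound 1 now leads from compound 3 to the unmeasured compound 4 `CCCCNc1nc(N)nc(C)c1CCCc1ccccc1`: here it reads (phenyl in place of ethyl on a saturated chain carbon, three bonds along the chain from an aromatic carbon). The two places are not identical, since in the earlier pair the change sits two bonds along the chain from an aromatic carbon and here three bonds along, so it is the same kind of change rather than the same change.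

Because the earlier step of a 1.5-fold higher number from compound 2 to compound 1 (0.18 log units; within the scatter) stayed within the scatter, the step from compound 3 to compound 4 is expected to be small as well, about a 1.2-fold higher number from compound 3 to compound 4 (0.09 log units; within the scatter). Compound 4 is therefore estimated at 1500 nM in this assay, expected between 600 nM and 4000 nM.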

Compound 4, half-maximal effective concentration: 749 nM
Beside the measured number, compound 4's estimate is 2.0-fold (0.30 log units) above it; measured number inside the range.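

Set on the core of compound 3, phenyl in place of ethyl gives a step in this assay (a 1.6-fold lower number from compound 3 to compound 4 (0.21 log units; within the scatter)) that stays within the scatter, like the earlier step, and the two steps cannot be told apart: the same change on two cores in this assay, a 1.5-fold higher number (0.18 log units; within the scatter) from compound 2 to compound 1 and a 1.6-fold lower number (0.21 log units; within the scatter) from compound 3 to compound 4, 2.5-fold (0.40 log units) apart, within the scatter of two such steps.

The other two new steps are also small, with phenyl in place of methyl (a 1.0-fold lower number from compound 2 to compound 4 (0.02 log units; within the scatter)) and benzyl in place of phenyl (a 1.6-fold lower number from compound 1 to compound 4 (0.20 log units; within the scatter)) both within the scatter. For the compounds shown here, this shows that, across these cores, the change carried over with no detectable difference, but it does not show that the change has a real effect in either direction, or that its effect is the same on both cores, since only two small steps can be compared.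

It stays open how an amine, a carboxylic acid or a much longer chain on this side chain would read in this assay; none of these appears among the compounds shown. On these data alone, it is also open whether the change would behave alike on a core that differs elsewhere.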